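The compounds below may be only part of what the source reports. "The series", "measured", "known", "first", "only" and "open" are said of these compounds alone.

In a functional assay on HeLa cells (Homo sapiens) for inhibition, read by CCK-8 assay, with a stated time of 72 h, tested at 8 uM (on this read-out lower numbers stand for less inhibition of growth and higher numbers for more inhibition of growth at the one concentration tested), three compounds have been measured so far. Compound 1, `Cc1cc(C)cc(SCc2ccc(/C=C/C(=O)Nc3ccccc3N)cc2)c1`, gives 3.39%, the lowest of the three numbers. Compound 3, `Nc1ccccc1NC(=O)c1ccc(CSc2ccc(C(F)(F)F)cn2)cc1`, gives 16.5%, and compound 2, `CCc1ccc(SCc2ccc(C(=O)Nc3ccccc3N)cc2)cc1`, gives 71%. Both lie beyond the scatter from compound 1. The compound still to be measured is compound 4, `Nc1ccccc1NC(=O)/C=C/c1ccc(CSCCc2ccccc2)cc1`, which has the same atoms as compound 1, joined differently: phenethyl in place of 3,5-dimethylphenyl on a sulfur. In words, phenethyl stands in place of 3,5-dimethylphenyl on a sulfur, and the rest of the core of compound 1 is kept. Within the data shown here, no measured pair of compounds shows a change of this kind, so the expectation rests on little. Compound 1 already sits close to the bottom of the read-out at 3.39%, which leaves little room for a fall. The estimated step of a number 8.6 percentage points higher from compound 1 to compound 4 (within the scatter) is a small rise, not expected to go beyond the usual scatter. For compound 4 the expected value is 12%, with an estimated range from 1% to 35%.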

Compound 4, percent growth inhibition at one concentration: 3.57%
For compound 4 the middle estimate is 8.4 percentage points above the measured one, within the range that was stated.
By their numbers in this assay, from the lowest: compounds 1 and 4 (each within the scatter of the next); then compound 3; then compound 2.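

In this assay, phenethyl in place of 3,5-dimethylphenyl on a sulfur gives a number 0.2 percentage points higher from compound 1 to compound 4 (within the scatter), the first step read at this position, and the two compounds cannot be told apart on this read-out. With the same atoms in both compounds, this pair shows that joining them differently at this sulfur, with the aromatic ring of carbon kept in the entering group, does not lift compound 4 clear of the scatter around compound 1. Nothing given here explains this result. As far as these compounds go, whether a longer chain, an amine or a carboxylic acid in place of phenethyl on that sulfur would separate from compound 1 stays open. Also open, from the compounds shown here alone, is whether the same exchange would give a similar step on a core other than that of compound 1.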